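Amide or urea on the pyrazole series: estimating compound 4

The source may hold more compounds than are shown below. What is called first, only, known or untested is meant among the compounds shown, and "the series" means these compounds.

Measured compounds:
compound 1 `COc1cc(-c2nn(-c3cccc(NC(=O)c4cccc(C(F)(F)F)c4)c3)cc2-c2ccncc2)ccc1Cl` gives 9960 nM
compound 2 `COc1cc(-c2nn(-c3cccc(NC(=O)Nc4cccc(C(F)(F)F)c4)c3)cc2-c2ccncc2)ccc1Cl` gives 2370 nM
compound 3 `COc1cc(-c2nn(-c3cccc(NC(=O)Nc4ccc(Cl)c(C(F)(F)F)c4)c3)cc2-c2ccncc2)ccc1Cl` gives 2600 nM

In a functional assay on MDA-MB-231 cells (Homo sapiens) for inhibition, read by sulforhodamine B assay, with a stated time of 48 h (on this read-out higher numbers stand for weaker inhibition of growth and lower numbers for stronger inhibition of growth), compound 3 stands second highest of the three numbers; its value sits within the scatter of compound 2 and well apart from compound 1. Compound 4 `COc1cc(-c2nn(-c3cccc(NC(=O)c4ccccc4)c3)cc2-c2ccncc2)ccc1Cl` differs from compound 3 in one place: phenyl in place of (4-chloro-3-(trifluoromethyl)phenyl)amino on a carbonyl carbon. Within the data shown here, two measured steps bear on this. Going from an amide to a urea gave a 4.2-fold lower number from compound 1 to compound 2 (0.62 log units; beyond the scatter) and a 3.8-fold lower number from compound 1 to compound 3 (0.58 log units; beyond the scatter); compound 4 reverses that move, returning to the amide. The further step a 1.1-fold higher number from compound 2 to compound 3 (0.04 log units; within the scatter) shows that the chloro group made no difference beyond the scatter, so its loss is not expected to matter. What is not known from these compounds is the effect of dropping the trifluoromethyl group. Compound 4 is therefore expected to give a higher number than compound 3, a step of about a 5.8-fold higher number from compound 3 to compound 4 (0.76 log units; beyond the scatter), landing near or above compound 1. The estimate for compound 4 is 15000 nM, within a range from 6000 nM to 40000 nM.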

Compound 4, concentration for total growth inhibition: 13700 nM
Beside the measured number, compound 4's estimate is 1.1-fold (0.04 log units) above it; the measured number falls inside the stated range.
By their numbers in this assay, from the lowest: compounds 2 and 3 (each within the scatter of the next); then compounds 1 and 4 (each within the scatter of the next).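

In this assay, among these compounds, removing the trifluoromethyl group from the phenyl of the amide makes no difference beyond the scatter (a 1.4-fold higher number from compound 1 to compound 4 (0.14 log units; within the scatter)), which gives the first direct reading of that group. The two ureas stand clearly apart from this plain phenyl amide (a 5.3-fold higher number from compound 3 to compound 4 (0.72 log units; beyond the scatter)) and (a 5.8-fold higher number from compound 2 to compound 4 (0.76 log units; beyond the scatter)), and each of these steps swaps the urea for the amide and also strips the ring of its substituents. Across these four compounds, then, the lower numbers go with the urea, whereas trifluoromethyl on the amide's phenyl does not shift the number beyond the scatter.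

Going by these compounds, what a urea carrying plain phenyl would give remains open, as does the effect of other groups on that ring, such as methoxy or an amine. Nothing measured here offers an explanation for these differences.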